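The source may hold more compounds than are shown below. What is called first, only, known or untested is meant among the compounds shown, and "the series" means these compounds.

Going by these compounds, in an ADME assay on HEK293 cells (Homo sapiens) for cytotoxicity, read by resazurin assay, with a stated time of 48 h (a lower number here means that less compound is tolerated, a higher number that more compound is tolerated), compound 1 (`O=S(=O)(Nc1ccc(-c2nc3ccccc3o2)cc1)c1cccc(F)c1`) gives > 100000 nM as a limit of the assay and not a number, so its exact standing is unknown. Compound 2 (`Cc1ccc(S(=O)(=O)Nc2ccc3oc(-c4ccccc4)nc3c2)cc1`) gives 75000 nM in this assay as a measured number. Compound 3 (`O=S(=O)(Nc1ccc(-c2nc3ccccc3o2)cc1)c1ccc(Cl)s1`) has 5-chlorothiophen-2-yl in place of 3-fluorophenyl on a sulfonyl sulfur and has yet to be measured. For the measured compounds named here, no measured step bears on this change, so only a moderate fall in this assay is expected, estimated as an at least 1.6-fold lower number from compound 1 to compound 3 (0.22 log units; that floor lies within the scatter) and uncertain in size. For compound 3 the expected value is 60000 nM with an estimated range from 18000 nM to 100000 nM in this measurement.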

Compound 3, half-maximal cytotoxic concentration: > 100000 nM
Compound 3: only a limit was reported (the forecaster's own chance of this, stated with the estimate: 40%); at least 1.6-fold (0.22 log units) between middle value and limit.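

For the compounds shown here, compound 1 and compound 3 both end at a limit in this assay, so no step between them can be read: the limit of > 100000 nM in this assay, at which 2 of the 3 values shown sit. The compounds shown leave open whether 5-chlorothiophen-2-yl in place of 3-fluorophenyl on a sulfonyl sulfur changes the tolerated concentration at all.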